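The source may report more compounds than this note shows. Statements on the series, on what has been measured and on what is new or still open speak of the compounds shown alone.

In a functional assay on L5178Y cells (Mus musculus) for antiproliferative activity, read by MTT assay (on this read-out higher numbers stand for weaker inhibition and lower numbers for stronger inhibition), three related compounds have been measured: compound 1 `CC(=O)c1ccc(OCCCN2CCN(c3ncccn3)CC2)cc1` gives 53.2 nM, compound 2 `CC(=O)c1ccc(OCCCCN2CCN(c3ncccn3)CC2)cc1` gives 31.6 nM and compound 3 `CC(=O)c1ccc(OCCCN2CCN(c3ccccn3)CC2)cc1` gives 27.1 nM. The value of compound 3 lies within the usual scatter of the other two, so these numbers do not set compound 3 apart from either neighbour.

Compound 4 `CC(=O)c1ccc(OCCCN2CCN(c3ccncc3)CC2)cc1` has the same atoms as compound 3, joined differently: pyridin-4-yl in place of pyridin-2-yl on an amine nitrogen in a ring. In words, this is pyridin-4-yl in place of pyridin-2-yl on an amine nitrogen in a ring.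

Going by the values given here, only one measured step changes the aromatic group at this place, pyridin-2-yl in place of pyrimidin-2-yl, and it amounts to a 2.0-fold lower number from compound 1 to compound 3 (0.29 log units; within the scatter). Among the compounds with values here, that step offers limited guidance, since no measured compound carries pyridin-4-yl. It is still the best available evidence, so no step beyond the scatter is expected in this assay, and neither direction is favoured. With so little evidence, the range has to stay fairly wide.

The expected value for compound 4 is 30 nM, with an estimated range from 12 nM to 75 nM. This estimate means an expected step of a 1.1-fold higher number from compound 3 to compound 4 (0.04 log units; within the scatter).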

Compound 4, half-maximal inhibitory concentration: 42.3 nM
For compound 4 the middle estimate is 1.4-fold (0.15 log units) below the measured one, and the stated range covers the measured number.
By their numbers in this assay, from the lowest: compounds 3, 2, 4 and 1 (each within the scatter of the next).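

In this assay, pyridin-4-yl in place of pyridin-2-yl keeps every atom of the group and only rejoins them, and this gives a 1.6-fold higher number from compound 3 to compound 4 (0.19 log units; within the scatter), so moving the ring nitrogen within this aromatic group produces no change that can be told apart from repeat-to-repeat noise. Set against the pyrimidin-2-yl group, the same pyridin-4-yl gives a 1.3-fold lower number from compound 1 to compound 4 (0.10 log units; within the scatter), which means all three aromatic groups seen on this amine nitrogen now lie within the scatter of one another, and this position has so far tolerated each of these swaps without a clear shift in the read-out. Nothing available on these compounds bears on this result beyond the numbers themselves.

The compounds shown leave open whether this tolerance extends to other groups at the same place, such as pyridin-3-yl, a plain phenyl ring with no ring nitrogen, or a phenyl ring carrying a carboxylic acid. Also open, as far as these compounds go, is how the longer chain of compound 2 would read when paired with pyridin-2-yl or pyridin-4-yl instead of pyrimidin-2-yl.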